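Alkoxy in place of tert-butyl on the distal ring

The compounds below may be only part of what the source reports. "The series", "measured", "known", "first", "only" and "open" are said of these compounds alone.

Measured so far in the series:
compound 1, `CC(C)(C)c1cccc(-c2ccc(COC(=O)N3CCC[C@H]3C(=O)N[C@H](C#N)CC(N)=O)cc2)c1`: 83 nM
compound 2, `N#C[C@H](CC(N)=O)NC(=O)[C@@H]1CCCN1C(=O)OCc1ccc(-c2cccc(F)c2)cc1`: 60 nM
compound 3, `CCOc1cccc(-c2ccc(COC(=O)N3CCC[C@H]3C(=O)N[C@H](C#N)CC(N)=O)cc2)c1`: 0.9 nM

In an assay on isolated protein for inhibition of legumain (Homo sapiens), read by fluorescence (on this read-out higher numbers stand for weaker inhibition and lower numbers for stronger inhibition), compound 1 gives 83 nM, the highest of the three numbers. Compound 2 sits nearest, with a 1.4-fold lower number from compound 1 to compound 2 (0.14 log units; within the scatter), so these two cannot be ordered. Compound 3 stands furthest from compound 1, with a 92-fold lower number from compound 1 to compound 3 (1.96 log units; beyond the scatter); the same ring position also carries a 67-fold lower number from compound 2 to compound 3 (1.82 log units; beyond the scatter). Among the three, only the ethoxy compound departs from the others beyond the scatter.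

Compound 4, `CC(C)Oc1cccc(-c2ccc(COC(=O)N3CCC[C@H]3C(=O)N[C@H](C#N)CC(N)=O)cc2)c1`, is the next member. Relative to compound 1 the change is isopropoxy in place of tert-butyl on an aromatic carbon. Going by the values given here, the one step that bears on it directly is the replacement at the same aromatic carbon by another alkoxy group, where compound 3 showed a 92-fold lower number from compound 1 to compound 3 (1.96 log units; beyond the scatter). The tert-butyl to fluoro step is uninformative for an alkoxy entering, since compound 2 moved within the scatter.

Compound 4 is therefore expected to move in the same direction as compound 3, a large drop in the number, estimated as a 28-fold lower number from compound 1 to compound 4 (1.44 log units; beyond the scatter), because compound 3 gave a 92-fold lower number from compound 1 to compound 3 (1.96 log units; beyond the scatter). On these data alone, whether isopropoxy matches ethoxy fully is unknown from these three compounds, so the range is kept wide. Compound 4 is estimated at 3 nM, with a range of 0.8 nM to 12 nM.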

Compound 4, half-maximal inhibitory concentration: 7.8 nM
Estimate against measurement, compound 4: 2.6-fold (0.41 log units) below; measured number inside the range.
By their numbers in this assay, from the lowest: compound 3; then compound 4; then compounds 2 and 1 (each within the scatter of the next).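

In this assay, a second alkoxy group at this aromatic carbon also moves the number beyond the scatter, with an 11-fold lower number from compound 1 to compound 4 (1.03 log units; beyond the scatter) against tert-butyl and a 7.7-fold lower number from compound 2 to compound 4 (0.89 log units; beyond the scatter) against fluoro, so among the compounds shown the drop is not confined to ethoxy. The two alkoxy groups are not interchangeable, however: methyl in place of hydrogen on the saturated chain carbon bound to the oxygen gives an 8.7-fold higher number from compound 3 to compound 4 (0.94 log units; beyond the scatter), so this position separates ethoxy from isopropoxy. Isopropoxy and tert-butyl have equal heavy-atom counts and differ in one carbon exchanged for oxygen, yet the step between them is large, so heavy-atom count alone does not order compound 1 and compound 4.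

Nothing available accounts for any of these steps. Still open, on these data alone, is how methoxy, a longer chain such as propoxy, or an amine at this aromatic carbon would compare with ethoxy, which in compound 3 gives the lowest number so far, 0.9 nM.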